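The compounds below may be only part of what the source reports. "The series", "measured", "known", "first", "only" and "open" are said of these compounds alone.

Series notes. Compound 1 `COc1nc(C)c(Nc2nc(Cl)cn([C@H](CO)C3CC3)c2=O)cc1C` carries a free hydroxyl on the saturated carbon; in an assay on frontal cortex for displacement of a labelled ligand from corticotropin-releasing factor receptor 1 (Rattus norvegicus), with a stated time of 2 h (on this read-out lower numbers stand for stronger inhibition and higher numbers for weaker inhibition), compound 1 gives 88 nM. Compound 2 `COc1nc(C)c(Nc2nc(Cl)cn([C@H](COC(=O)c3ccccc3)C3CC3)c2=O)cc1C` gives 1.5 nM, and compound 3 `COc1nc(C)c(Nc2nc(Cl)cn([C@H](COC(=O)Nc3ccccc3)C3CC3)c2=O)cc1C` gives 1.5 nM. Compound 3 stands level with compound 2 at the digits shown, the two together the lowest of the three numbers, and its furthest neighbour is compound 1: a 59-fold lower number from compound 1 to compound 3 (1.77 log units; beyond the scatter). The matching step a 59-fold lower number from compound 1 to compound 2 (1.77 log units; beyond the scatter) and the step of no change at the digits printed from compound 2 to compound 3 (within the scatter) show that replacing the hydrogen on that oxygen is what moves the number, while benzoyl and phenylcarbamoyl are not separated on this read-out.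

Compound 4 `COc1nc(C)c(Nc2nc(Cl)cn([C@H](COc3ccccn3)C3CC3)c2=O)cc1C` differs from compound 3 at the same oxygen: pyridin-2-yl in place of phenylcarbamoyl on an oxygen on a saturated carbon. Going by the values given here, no measured step covers an aromatic ring bound directly to the oxygen without a carbonyl. The two large steps from compound 1 bear on it only in that the hydrogen on the oxygen is again replaced; the hydrogen-bond donor goes with the leaving group and a hydrogen-bond acceptor remains. The step expected is a 3.3-fold higher number from compound 3 to compound 4 (0.52 log units; beyond the scatter), a modest loss rather than a return to the number of compound 1. Estimate for compound 4 in this assay: 5 nM, range 1.5 nM to 30 nM.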

Compound 4, half-maximal inhibitory concentration: 1.2 nM
Compound 4: middle estimate off by 4.2-fold (0.62 log units), on the high side; measured number below the stated range.
By their numbers in this assay, from the lowest: compounds 4, 2 and 3 (each within the scatter of the next); then compound 1.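

Among the compounds shown, a carbonyl on this oxygen is not required: pyridin-2-yl, an aromatic ring bound directly to the oxygen with 6 heavy atoms against 9 for phenylcarbamoyl, is not separated from phenylcarbamoyl (a 1.3-fold lower number from compound 3 to compound 4 (0.10 log units; within the scatter)) or from benzoyl (a 1.3-fold lower number from compound 2 to compound 4 (0.10 log units; within the scatter)) in this assay. The large step from the free hydroxyl (a 73-fold lower number from compound 1 to compound 4 (1.87 log units; beyond the scatter)) is therefore seen with three different groups on the oxygen, one of them joined without a carbonyl, and compound 1 is the only one of the four that keeps the hydrogen there. No measurement at hand accounts for this tolerance at the position or for the level numbers of the three substituted compounds.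

The compounds shown leave open whether the ring nitrogen of pyridin-2-yl contributes anything, which a plain phenyl ether on the same oxygen would address, and whether an aromatic ring is needed at all, which a methyl ether or a longer alkyl chain would address. Also open, as far as these compounds go, is whether the oxygen itself can be exchanged, as with an amine at that place, or whether a carboxylic acid on the ring would be accepted.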